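The compounds below may be only part of what the source reports. "The series", "measured", "known", "first", "only" and "open" are said of these compounds alone.

Measured in a functional assay (trachea) with Cavia porcellus as the target; a higher number here means a weaker inhibitor, a lower number a stronger inhibitor:
- compound 1 `Cn1nc(-c2cccnc2)c2ccccc2c1=O`: 11500 nM
- compound 2 `CC(C)=CCn1nc(-c2cccnc2)c2ccccc2c1=O`: 1380 nM
- compound 3 `CCOC(=O)CCCn1nc(-c2cccnc2)c2ccccc2c1=O`: 10000 nM

Compound 3, at 10000 nM, shows a 1.2-fold lower number from compound 1 to compound 3 (0.06 log units; within the scatter), while the gap to the best measured number is a 7.2-fold higher number from compound 2 to compound 3 (0.86 log units; beyond the scatter). The next structure is compound 4 `O=c1c2ccccc2c(-c2cccnc2)nn1CCSc1ncccn1`, which carries (pyrimidin-2-yl)sulfanyl in place of (ethoxycarbonyl)methyl on a saturated chain carbon, two bonds along the chain from an aromatic nitrogen.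

Among the measured compounds shown here, no measured compound carries this group, so the evidence is only indirect. The same part of the molecule produced an 8.3-fold lower number from compound 1 to compound 2 (0.92 log units; beyond the scatter), so changes there can move the number modestly, yet compound 3 shows that one such change, a 1.2-fold lower number from compound 1 to compound 3 (0.06 log units; within the scatter), need not do so. With compound 3 near the top of the measured span at 10000 nM, a modest move to a lower number is expected in this assay, though none beyond the scatter remains possible. The expected change is a 2.5-fold lower number from compound 3 to compound 4 (0.40 log units; beyond the scatter). Compound 4 is estimated at 4000 nM, with an expected range of 1300 nM to 12000 nM.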

Compound 4, half-maximal inhibitory concentration: 11000 nM
Beside the measured number, compound 4's estimate is 2.8-fold (0.44 log units) below it, within the range that was stated.
By their numbers in this assay, from the lowest: compound 2; then compounds 3, 4 and 1 (each within the scatter of the next).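

In this assay, (pyrimidin-2-yl)sulfanyl in place of (ethoxycarbonyl)methyl, on a saturated chain carbon two bonds along the chain from an aromatic nitrogen, gives a 1.1-fold higher number from compound 3 to compound 4 (0.04 log units; within the scatter), and the comparison with the simplest compound gives a 1.0-fold lower number from compound 1 to compound 4 (0.02 log units; within the scatter). A second, quite different side chain, this one carrying an aromatic ring, thus joins the ester chain in showing no separation from compound 1, while an 8.0-fold higher number from compound 2 to compound 4 (0.90 log units; beyond the scatter) leaves compound 2 apart, so a larger group at this position does not by itself lower the number, with compounds 3 and 4 going against compound 2. No available measurement explains this difference.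

Going by these compounds, it remains open whether a saturated 3-methylbutyl chain would match compound 2, which would test the role of its double bond. Also open, on these data alone, is whether a carboxylic acid in place of the ethyl ester, or a terminal amine, would stay level with compounds 3 and 4.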